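Benzyloxy for methoxy on an acetamide scaffold

A few compounds are considered here, and "the series" means these few. Any claim that something is new, unique, unknown or untested is made for them only; others in the source may bear on it.

Measured compounds:
compound 1 `CCN(CC)C(=O)c1nc2ccccc2n1Cc1ccccc1`: > 10000 nM
compound 2 `CCN(CC)C(=O)c1nc2ccccc2n1Cc1ccc(OC)nc1`: > 10000 nM
compound 3 `COc1ccc(CN(C(C)=O)c2cc(C)cc(C)c2)cc1`: 500 nM

In an assay on membranes from HEK293 cells for displacement of a labelled ligand from Translocator protein (Homo sapiens), read by scintillation counting, with a stated time of 90 min (on this read-out lower numbers stand for stronger inhibition and higher numbers for weaker inhibition), compound 1 gives only a limit, > 10000 nM. Compound 2 likewise gives only a limit in this assay, > 10000 nM. The step from compound 1 to compound 2, a step that the two limits leave unreadable from compound 1 to compound 2, therefore cannot be read, as both values sit at the limit of > 10000 nM in this assay, at which 2 of the 3 values shown sit. Compound 3 holds the only number shown; in this assay compound 3 gives 500 nM.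

Compound 4 `CC(=O)N(Cc1ccc(OCc2ccccc2)cc1)c1cc(C)cc(C)c1` differs from compound 3 by phenyl in place of hydrogen on a saturated chain carbon bound to an oxygen on an aromatic ring. None of the measured steps touches this position, and the one step that is shown cannot be sized, so nothing measured bears on the change directly. On that basis the expected step in this assay, a 2.0-fold lower number from compound 3 to compound 4 (0.30 log units; within the scatter), is small, with at most a modest gain in strength that may not exceed the scatter. Compound 4 is therefore estimated at 250 nM, within a range from 60 nM to 1200 nM.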

Compound 4, inhibition constant: 377 nM
Compound 4: middle estimate off by 1.5-fold (0.18 log units), on the low side; the range from low to high includes it.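

In this assay, going from methoxy to benzyloxy gives a 1.3-fold lower number from compound 3 to compound 4 (0.12 log units; within the scatter), so phenyl in place of hydrogen on a saturated chain carbon bound to an oxygen on an aromatic ring leaves the value within the scatter. The earlier compounds could not show this: the only earlier step, between compound 1 and compound 2, cannot be read, and neither compound gives more than a limit, so this is the only readable step among the compounds shown. Nothing shown gives a reason for this outcome.

As far as these compounds go, it stays open whether a longer chain between the oxygen and the phenyl ring, or an amine or a carboxylic acid on that ring, would move the value beyond the scatter. No compound shown changes the acetamide part, so its role also remains open.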